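The compounds below may be only part of what the source reports. "The series", "measured", "known", "first", "only" and "open" are said of these compounds alone.

Measured in an ADME assay on HeLa cells (Homo sapiens) for cytotoxicity, read by crystal violet staining, with a stated time of 72 h; on this read-out higher numbers stand for lower toxicity in this test and lower numbers for higher toxicity in this test:
- compound 1 `CCOC(=O)c1cc(CCCOc2c(C)cc(-c3noc(C(F)(F)F)n3)cc2C)on1`: 17200 nM
- compound 2 `Cc1cc(-c2noc(C(F)(F)F)n2)cc(C)c1OCCCc1cc(C(=O)OC(C)C)no1`: 17900 nM
- compound 3 `Cc1cc(-c2noc(C(F)(F)F)n2)cc(C)c1OCCCc1cc(-c2ccccc2)no1`: > 100000 nM, a limit and not a number

Compound 3 stands at the limit of > 100000 nM in this assay, at which 1 of the 3 values shown sits. Compound 4 `Cc1cc(-c2noc(C(F)(F)F)n2)cc(C)c1OCCCc1cc(-c2ccc(OC(F)(F)F)cc2)no1` has trifluoromethoxy in place of hydrogen on an aromatic carbon, para to a large group: trifluoromethoxy in place of hydrogen on an aromatic carbon.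

Among the compounds with values here, no measured step makes this change. The nearest are an at least 5.8-fold higher number from compound 1 to compound 3 (0.76 log units; beyond the scatter) and an at least 5.5-fold higher number from compound 2 to compound 3 (0.74 log units; beyond the scatter), both beyond the scatter, and both introduce the phenyl that now takes the new group. a 1.0-fold higher number from compound 1 to compound 2 (0.02 log units; within the scatter) lies within the scatter and says little here. Neither of the nearest steps fixes a size, since each ends at a limit. The expected step is an at least 1.5-fold lower number from compound 3 to compound 4 (0.18 log units; that floor lies within the scatter), modest and toward lower numbers in this assay, or none that can be read. For compound 4 the estimated value is 65000 nM, with an expected range from 25000 nM to 100000 nM.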

Compound 4, half-maximal cytotoxic concentration: > 100000 nM
Compound 4 gave a limit, no number; the forecaster's own chance of this, stated with the estimate: 45%; middle value at least 1.5-fold (0.18 log units) from the limit.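

In this assay compound 4 gives > 100000 nM, a limit and not a number, so a phenyl carrying trifluoromethoxy stays at the limit just as the bare phenyl did. The separation from both esters therefore holds for a substituted phenyl too: an at least 5.5-fold higher number from compound 2 to compound 4 (0.74 log units; beyond the scatter) and an at least 5.8-fold higher number from compound 1 to compound 4 (0.76 log units; beyond the scatter). The step that adds trifluoromethoxy itself cannot be read, and the two phenyl compounds now share one ceiling: the limit of > 100000 nM in this assay, at which 2 of the 4 values shown sit.

From the compounds shown here alone, how far compound 3 and compound 4 lie past that limit stays open. So does whether an amine or a carboxylic acid in place of trifluoromethoxy would give a readable number.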